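Imidazoline-indane agonists: amide in place of sulfonamide

The source may report more compounds than this note shows. Statements on the series, on what has been measured and on what is new or still open speak of the compounds shown alone.

Measured so far:
compound 1, `Cc1c(OCC2=NCCN2)ccc(Cl)c1NS(C)(=O)=O`, 60%
compound 2, `CCS(=O)(=O)Nc1cccc2c1CCC2c1ncc[nH]1`, 86%
compound 3, `Clc1ccc2c(c1-c1ccn[nH]1)CCC2c1ncc[nH]1`, 40%

In a functional assay on CHO cells for agonist activity at Alpha-1A adrenergic receptor (Homo sapiens), read by FLIPR and calcium flux (a lower number here means a smaller maximal response, a higher number a larger maximal response), compound 2 gives 86%, the highest of the three numbers. Compound 1 gives 60%, a number that lies well beyond the usual scatter below compound 2, and compound 3 gives 40%, the furthest below compound 2, again beyond the scatter. Within the data shown here, only the numbers themselves are known for these pairs; no single-change step between measured compounds is available, and compound 2 therefore has no measured neighbour from which the effect of a change on its core could be read.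

Compound 4, `CNC(=O)c1cccc2c1CCC2c1ncc[nH]1`, has not yet been measured. It differs from compound 2 in one place: methylcarbamoyl in place of (ethylsulfonyl)amino on an aromatic carbon. Without a measured step of this kind, the expectation rests on the spread of the three numbers alone. A downward step of moderate size is expected from compound 2 to compound 4 in this assay, a number 16 percentage points lower from compound 2 to compound 4 (beyond the scatter), though one within the scatter cannot be excluded. Compound 4 is expected to give 70% in this assay, within a range from 40% to 95%.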

Compound 4, largest response reached (Emax), in percent of the reference or control that the assay uses: 59%
For compound 4 the middle estimate is 11 percentage points above the measured one; measured number inside the range.
By their numbers in this assay, from the lowest: compound 3; then compounds 4 and 1 (each within the scatter of the next); then compound 2.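

Methylcarbamoyl in place of (ethylsulfonyl)amino on an aromatic carbon gives the first single-change step in this set in this assay, a number 27 percentage points lower from compound 2 to compound 4 (beyond the scatter). The maximal response at this position therefore depends on which of these two groups it carries, yet compound 4 gives 59% with methylcarbamoyl there, so the sulfonamide group of compound 2 is not required for a measurable response in this assay on this core. Nothing at hand accounts for the size or direction of this step.

The change alters the link to the aromatic carbon and the end of the chain together, so the compounds shown do not separate the effect of the sulfonyl-to-carbonyl exchange from that of ethyl versus methyl. Methylsulfonylamino, acetylamino, an unsubstituted carboxamide or a carboxylic acid on the same aromatic carbon would each help to separate these contributions, and any of them could show whether the response in this assay follows the link, the chain or neither.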